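The source may hold more compounds than are shown below. What is called first, only, known or untested is meant among the compounds shown, and "the series" means these compounds.

Three compounds from one study are considered here. From the compounds shown here alone, compound 1, `c1ccc(Sc2nc(Sc3ccccc3)c3ncn(C4CNc5ccccc5CO4)c3n2)cc1`, is recorded in an ADME assay on MCF-10A cells (Homo sapiens) for cytotoxicity, read by sulforhodamine B assay, with a stated time of 3 days (on this read-out lower numbers stand for stronger inhibition and higher numbers for weaker inhibition), as "not determined" (no result reported), so its activity remains unknown. Compound 2, `Nc1ccccc1S(=O)(=O)N1CC(n2cnc3c(Cl)nc(Cl)nc32)OCc2ccccc21`, carries a shared core that also appears in compound 3, and in this assay compound 2 gives 1520 nM. Within the data shown here, this is the only number that has been reported, so compound 2 stands alone as the single reference point; there is no second measured compound to compare it with, and therefore no measured step to draw on.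

Compound 3, `O=[N+]([O-])c1ccc(S(=O)(=O)N2CC(n3cnc4c(Cl)nc(Cl)nc43)OCc3ccccc32)cc1`, differs from compound 2 in one place: 4-nitrophenyl in place of 2-aminophenyl on a sulfonyl sulfur. Since nothing has been measured for any pair of compounds in this series, the effect of this exchange on this assay cannot be read off from the data. Among the measured compounds shown here, with only one anchoring value, the expectation is a step from compound 2 to compound 3 that stays within the usual scatter, a 1.3-fold higher number from compound 2 to compound 3 (0.12 log units; within the scatter), with no direction to favour. Compound 3 is therefore estimated at 2000 nM, within a range from 700 nM to 6000 nM.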

Compound 3, half-maximal inhibitory concentration: 1830 nM
Beside the measured number, compound 3's estimate is 1.1-fold (0.04 log units) above it; the range from low to high includes it.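

In this assay, among these compounds, putting 4-nitrophenyl in place of 2-aminophenyl on a sulfonyl sulfur gives a 1.2-fold higher number from compound 2 to compound 3 (0.08 log units; within the scatter), the first measured step. The exchange is not a small one on paper: the group that enters has more heavy atoms and 0 hydrogen-bond donors, whereas the group that leaves has 1, yet the read-out does not separate the two compounds. For this one pair, then, the change at this position leaves the cytotoxicity number where repeat measurements could also have put it, and no measurement shown here offers an explanation for that.

This single exchange alters both the group on the phenyl ring and its place on that ring, so a comparison with 4-aminophenyl or 2-nitrophenyl would be needed to tell those two changes apart. From the compounds shown here alone, it also remains open whether the same holds when the phenyl ring on the sulfonyl sulfur gives way to something quite different, such as a short alkyl chain or a phenyl ring carrying a carboxylic acid.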